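The compounds below may be only part of what the source reports. "The series", "measured", "known", "first", "only" and "open" are said of these compounds alone.

Three members of this series share one core and differ only in the group attached to the amide. In an assay on CHO-K1 cells for displacement of a labelled ligand from prostaglandin E2 receptor EP1 subtype (Homo sapiens) (a lower number here means a stronger inhibitor, a higher number a weaker inhibitor), compound 1 `Cc1cc(C(=O)Nc2ccc(F)cc2)nn1Cc1cc(Cl)ccc1OCc1ccccc1` gives 79.4 nM, compound 2 `Cc1cc(NC(=O)C2CCCC2)nn1Cc1cc(Cl)ccc1OCc1ccccc1` gives 15.9 nM, and compound 3 `Cc1cc(NC(=O)c2c(F)cccc2F)nn1Cc1cc(Cl)ccc1OCc1ccccc1` gives 12.6 nM. Compound 3 has the lowest number of the three, but its gap to compound 2 is within the scatter, so the two cannot be ordered; only the gap to compound 1 is clear, seen in a 6.3-fold lower number from compound 1 to compound 3 (0.80 log units; beyond the scatter) and, for compound 2, in a 5.0-fold lower number from compound 1 to compound 2 (0.70 log units; beyond the scatter). Compound 4 `Cc1cc(NC(=O)OC(C)(C)C)nn1Cc1cc(Cl)ccc1OCc1ccccc1` keeps the amide-type nitrogen and changes the group on the carbonyl: tert-butoxy in place of 2,6-difluorophenyl on a carbonyl carbon. The step that bears on this is a 1.3-fold lower number from compound 2 to compound 3 (0.10 log units; within the scatter), where an aliphatic ring and an aromatic ring on the same carbonyl carbon gave numbers within the scatter of each other. On that basis the expected step is a 2.0-fold higher number from compound 3 to compound 4 (0.30 log units; within the scatter) in this assay, a small change, if any. Compound 4 is therefore estimated at 25 nM, with a range from 8 nM to 80 nM.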

Compound 4, half-maximal inhibitory concentration in the prostaglandin E2 receptor EP1 subtype assay: 25.1 nM
The estimate for compound 4 lay 1.0-fold (0.00 log units) below the measured number; the measured number falls inside the stated range.
By their numbers in the prostaglandin E2 receptor EP1 subtype assay, from the lowest: compounds 3, 2 and 4 (each within the scatter of the next); then compound 1.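

The earlier compounds shown here carried only a ring on this carbonyl carbon, and the open-chain tert-butoxy shows that a ring is not needed there to stay in the same range in the prostaglandin E2 receptor EP1 subtype assay: the changes are a 2.0-fold higher number from compound 3 to compound 4 (0.30 log units; within the scatter) and a 1.6-fold higher number from compound 2 to compound 4 (0.20 log units; within the scatter). The clear gap to the reversed amide also survives this change of group in the prostaglandin E2 receptor EP1 subtype assay, with a 3.2-fold lower number from compound 1 to compound 4 (0.50 log units; beyond the scatter), although it is the smallest of the three such gaps in number. In a physicochemical assay for lipophilicity, at pH 7.4 (on this read-out higher numbers stand for higher lipophilicity and lower numbers for lower lipophilicity), compound 3 gives > 3.7, which is a limit of the assay. In the physicochemical assay compound 4 gives > 3.7, which is also a limit of the assay. In the physicochemical assay the step for the same change cannot be read, as both values are limits of the assay: the limit of > 3.7 in the physicochemical assay, at which 2 of the 2 values shown sit.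

The compounds shown leave open whether the carbonyl carbon keeps this range with a dimethylamino group or a longer alkyl chain in place of tert-butoxy. They also leave open how a carboxylic acid at the end of such a chain would fare in the prostaglandin E2 receptor EP1 subtype assay, and what lies behind the numbers seen so far.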